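The source may report more compounds than this note shows. Statements on the series, on what has been measured and on what is new or still open speak of the compounds shown alone.

Measured compounds:
Compound 1 `COc1cc(-c2nn(-c3cccc(NC(=O)Nc4cc(C(F)(F)F)cc(C(F)(F)F)c4)c3)cc2-c2ccncc2)ccc1Cl` gives 2070 nM.
Compound 2 `O=C(Nc1cccc(-n2cc(-c3ccncc3)c(-c3ccc(Cl)c(O)c3)n2)c1)Nc1ccc(Cl)c(Cl)c1` gives 12200 nM.

Both compounds were tested in a functional assay on SNB-75 cells (Homo sapiens) for inhibition, read by sulforhodamine B assay, with a stated time of 48 h; on this read-out lower numbers stand for stronger inhibition of growth and higher numbers for weaker inhibition of growth. Among the two numbers, compound 1 stands lowest: it gives 2070 nM, while compound 2 gives 12200 nM, a gap that lies beyond the usual scatter of this assay. Going by the values given here, no pair of measured compounds differs in a single place, so no measured step is available to guide an estimate.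

Compound 3 `COc1cc(-c2nn(-c3cccc(NC(=O)Nc4cccc(C(F)(F)F)c4)c3)cc2-c2ccncc2)ccc1Cl` has not yet been measured. It differs from compound 1 by hydrogen in place of trifluoromethyl on an aromatic carbon of a six-membered aromatic ring of carbon only, meta to a large group and meta to the remaining trifluoromethyl group. Among the compounds with values here, with no measured step of this kind, the size of the change can only be judged loosely; a modest weakening relative to compound 1 is expected, though a result within the scatter would not be surprising. The estimated step from compound 1 to compound 3 is a 1.9-fold higher number from compound 1 to compound 3 (0.29 log units; within the scatter). Compound 3 is therefore expected to give about 4000 nM in this assay, within a range from 1500 nM to 12000 nM.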

Compound 3, concentration for total growth inhibition: 4500 nM
Estimate against measurement, compound 3: 1.1-fold (0.05 log units) below; low and high end bracket the measured number.
By their numbers in this assay, from the lowest: compound 1; then compound 3; then compound 2.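

In this assay, the change from trifluoromethyl to hydrogen on this aromatic carbon, meta to a large group and meta to a trifluoromethyl group, gives a 2.2-fold higher number from compound 1 to compound 3 (0.34 log units; beyond the scatter) and is a modest loss of growth inhibition. Going by these compounds alone, the earlier compounds differed in more than one place, so they could not show what this position alone contributes; this pair shows that the second trifluoromethyl group on the ring has a measurable but limited effect, since compound 3 still gives 4500 nM with only one such group in place. Nothing available here bears on why the step has this size.

The compounds shown leave open whether another group at this position, such as a nitrile, a methyl group or an amine, would give a number closer to that of compound 1 or move further from it. They also leave open what hydrogen in place of the remaining trifluoromethyl group would do, and whether this step would keep its size on a different substitution pattern elsewhere in the core.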